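Half-life after a ring swap on compound 2

This account rests on a few compounds, and the source may have more. Where it says the series, first, only, none or still open, it means among the compounds named here.

- compound 1 `O=c1nc(N2CCN(CC3CCCCC3)CC2)sc2c([N+](=O)[O-])cc(C(F)(F)F)cc12`: 2.87 h
- compound 2 `O=c1nc(N2CCC3(CCN(Cc4ccc(Br)cc4)CC3)CC2)sc2c([N+](=O)[O-])cc(C(F)(F)F)cc12`: 10.7 h

In an ADME assay on the whole organism (strain ICR) for metabolic stability, with Mus musculus as the target, read by HPLC, at a dose of 50 mg/kg by the oral route (on this read-out lower numbers stand for a shorter-lived compound and higher numbers for a longer-lived compound), compound 2 gives the higher of the two numbers, 10.7 h, beyond the usual scatter above compound 1.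

Compound 3 `O=c1nc(N2CCC3(CCN(Cc4cc(F)cc(F)c4)CC3)CC2)sc2c([N+](=O)[O-])cc(C(F)(F)F)cc12` differs from compound 2 in one place: 3,5-difluorophenyl in place of 4-bromophenyl on a saturated chain carbon bound to an amine nitrogen in a ring. The new 3,5-difluorophenyl stands in place of 4-bromophenyl on a saturated chain carbon bound to an amine nitrogen in a ring.

Within the data shown here, no measured pair shows what this swap does, so only a small change is expected. The estimate is a 1.5-fold lower number from compound 2 to compound 3 (0.18 log units; within the scatter), a slight fall that stays within the scatter. Compound 3 is expected at 7 h, with a range of 3 h to 14 h.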

Compound 3, half-life: 4.68 h
The estimate for compound 3 lay 1.5-fold (0.17 log units) above the measured number; measured number inside the range.
By their numbers in this assay, from the lowest: compounds 1 and 3 (each within the scatter of the next); then compound 2.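

In this assay, 3,5-difluorophenyl in place of 4-bromophenyl on a saturated chain carbon bound to an amine nitrogen in a ring gives a 2.3-fold lower number from compound 2 to compound 3 (0.36 log units; beyond the scatter) even though both groups have the same carbon ring and neither has a hydrogen-bond donor or acceptor. The half-life at this place therefore depends on which halogens the ring carries and where they sit. Nothing measured here gives a reason for the step.

A plain phenyl or 4-chlorophenyl at the same place could help separate the roles of halogen type and halogen placement. From the compounds shown here alone, whether another core would respond in the same way also remains open.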